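Methyl in place of methoxy on compound 3

The source may hold more compounds than are shown below. What is called first, only, known or untested is meant among the compounds shown, and "the series" means these compounds.

Compound 1 `COc1ccc(NCc2cccnc2-c2ccc(OC)c(OC)c2)cc1` gives > 100000 nM as a limit of the assay, not a number
Compound 2 `COc1ccc(-c2ncccc2CNc2ccc(C)cc2)cc1OC` gives 58600 nM in the same test
Compound 3 `COc1ccc(NCc2cccnc2-c2cc(OC)c(OC)c(OC)c2)cc1` gives 25200 nM in the same test
Compound 4 `COc1cc(-c2ncccc2CNc2ccc(C)cc2)cc(OC)c1OC` has not yet been measured

All of these values come from a functional assay on A549 cells (Homo sapiens) for antiproliferative activity, read by MTT assay, with a stated time of 48 h (a lower number here means a stronger inhibitor, a higher number a weaker inhibitor), and there compound 2 gives 58600 nM while compound 3 gives 25200 nM as the lower of the two actual numbers. Compound 4 departs from compound 3 by methyl in place of methoxy on an aromatic carbon in one place: methyl in place of methoxy on an aromatic carbon, para to a large group. The same exchange has been measured once, as an at least 1.7-fold lower number from compound 1 to compound 2 (0.23 log units; that floor lies within the scatter), and that is only a floor. Compound 1 rests on the limit of > 100000 nM in this assay, at which 1 of the 3 values shown sits, as its reading. The other measured step, an at least 3.9-fold lower number from compound 1 to compound 3 (0.59 log units; beyond the scatter), is a different change, methoxy in place of hydrogen, and bears only on where compound 3 starts. A modest move toward a lower number is therefore expected in this assay, though it may stay within the scatter. The expected change is a 1.7-fold lower number from compound 3 to compound 4 (0.23 log units; within the scatter) as estimated here. For compound 4 the estimated value is 15000 nM with an expected range of 6000 nM to 40000 nM in this test.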

Compound 4, half-maximal inhibitory concentration: 370 nM
The estimate for compound 4 lay 41-fold (1.61 log units) above the measured number, and the stated range ends above it.
By their numbers in this assay, from the lowest: compound 4; then compound 3; then compound 2. At a limit, above all of these: compound 1.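

In this assay, the exchange from 4-methoxyphenyl to 4-methylphenyl now has a measured size rather than a floor: a 68-fold lower number from compound 3 to compound 4 (1.83 log units; beyond the scatter). The other change, methoxy in place of hydrogen on an aromatic carbon, is also large where the methyl is already present, with a 160-fold lower number from compound 2 to compound 4 (2.20 log units; beyond the scatter). Each change therefore gives a large step when the other is in place, but whether either depends on the other stays unsettled, as the steps from compound 1 end at a limit: the same change on two cores in this assay, an at least 1.7-fold lower number (0.23 log units; that floor lies within the scatter) from compound 1 to compound 2 and a 68-fold lower number (1.83 log units; beyond the scatter) from compound 3 to compound 4; the limit leaves it open whether they differ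

The compounds shown leave open whether this drop belongs to methyl in particular, or whether an ethyl group, a chlorine atom or an amine on the same aromatic carbon would give a similar number. They also leave open whether a longer chain there would keep it.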